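A few compounds are considered here, and "the series" means these few. Any claim that something is new, unique, unknown or untested is made for them only; others in the source may bear on it.

In an ADME assay on the whole organism (plasma, Mus musculus, strain CD1), read by LC-MS, with a stated time of 24 h (a higher number here means a larger unbound share of the compound, a lower number a smaller unbound share), compound 2 `O=C(O)Cc1nn(Cc2cn3cc(OCC4CC4)c(Cl)cc3n2)c2ccccc2c1=O` gives 0.045. Compound 1 `O=C(O)Cn1nc(Cc2nc3cc(Cl)c(OCC(F)F)cc3[nH]2)c2ccccc2c1=O` gives 0.038, which lies within the scatter of compound 2. Compound 3 `C[C@H](C(=O)O)n1nc(Cn2cc3cc(OCC4CC4)c(Cl)cc3n2)c2ccccc2c1=O` gives 0.011, a gap to compound 2 that lies beyond the scatter.

The unmeasured compound 4 `C[C@H](C(=O)O)c1nn(Cc2cn3cc(OCC4CC4)c(Cl)cc3n2)c2ccccc2c1=O` is compound 2 with a single change: methyl in place of hydrogen on a saturated chain carbon bound to an aromatic carbon and a carbonyl carbon. This is methyl in place of hydrogen on a saturated chain carbon bound to an aromatic carbon and a carbonyl carbon, so carboxymethyl becomes 1-carboxyethyl. Among the compounds with values here, no two measured compounds differ in one place only, so there is no direct precedent for this step. Compound 3 also bears 1-carboxyethyl, and its 0.011 hints at a lower number, though it differs from compound 2 elsewhere too. The estimated change is a 1.8-fold lower number from compound 2 to compound 4 (0.26 log units; within the scatter), a modest fall that is expected to stay within the scatter. The estimate in this assay for compound 4 is 0.025, with an expected range of 0.011 to 0.05.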

Compound 4, unbound fraction: 0.032
The estimate for compound 4 lay 1.3-fold (0.11 log units) below the measured number; measured number inside the range.
By their numbers in this assay, from the lowest: compound 3; then compounds 4, 1 and 2 (each within the scatter of the next).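

Within the data shown here, compound 2 and compound 4 are the first pair here that differ in one place only, so this assay can be read directly for this change as a 1.4-fold lower number from compound 2 to compound 4 (0.15 log units; within the scatter) and shows its size without any other difference in the way. Because that step stays within the scatter, methyl in place of hydrogen on this saturated chain carbon, which turns carboxymethyl into 1-carboxyethyl, leaves the two compounds indistinguishable in unbound share. Nothing available offers an explanation for this result.

The compounds shown leave open whether an ethyl group, or a second methyl, on this same carbon would carry the number beyond the scatter. They also leave open whether the mirror-image form of compound 4 would give a number within the scatter of compound 4.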